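A few compounds are considered here, and "the series" means these few. Any claim that something is new, unique, unknown or untested is made for them only; others in the source may bear on it.

Compound 1 `C=C1CCC(c2csc(/C=C(\C)C(N)=O)c2)CC1`: 5010 nM
Compound 2 `C/C(=C\c1cc(-c2ccc(C)nc2)co1)C(N)=O`: > 50000 nM
Compound 3 `C/C(=C\c1cc(-c2ccc(C)cc2)cs1)C(N)=O`: > 50000 nM

All three share one core and were tested in a functional assay on HeLa cells (Homo sapiens) for cytotoxicity, read by CCK-8 assay, with a stated time of 24 h; on this read-out higher numbers stand for weaker inhibition and lower numbers for stronger inhibition. Going by the values given here, compound 1 is the only one with an actual number. Compound 2 gives only a limit of this assay, > 50000 nM. Compound 3 also reaches only a limit in this assay, > 50000 nM, so all that is known of it is weak inhibition, in keeping with the limit of > 50000 nM in this assay, at which 2 of the 3 values shown sit. Compound 4 `COc1ccc(-c2csc(/C=C(\C)C(N)=O)c2)cc1` differs from compound 3 in one place: methoxy in place of methyl on an aromatic carbon. Among the compounds with values here, no measured pair shows what such a change does here. Compound 4 is therefore expected to stay near the limit, at an estimated 60000 nM (range 20000 nM to 200000 nM), an expected step that the limit leaves unreadable from compound 3 to compound 4 that lies within the scatter.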

Compound 4, half-maximal inhibitory concentration: > 50000 nM
Compound 4: a limit, no number; the forecaster's own chance of this, stated with the estimate: 75%; the middle value is on the limit's open side.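

Going by these compounds alone, compound 3 and compound 4 each give only a limit in this assay, not a number, so no step between them can be read: the limit of > 50000 nM in this assay, at which 3 of the 4 values shown sit. Left open is whether methoxy in place of methyl on an aromatic carbon changes inhibition at all.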